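Swapping the Amino Group for Methoxy on the Benzyl Ring

A few compounds are considered here, and "the series" means these few. Any claim that something is new, unique, unknown or untested is made for them only; others in the source may bear on it.

For the measured compounds named here, in a functional assay on PC-3 cells (Homo sapiens) for antiproliferative activity, read by MTT assay, with a stated time of 48 h (a lower number here means a stronger inhibitor, a higher number a weaker inhibitor), compound 2 `COc1ccc(CN(C(=O)CSc2nc3ccccc3s2)c2cc(OC)c(OC)c(OC)c2)cc1N` gives 7510 nM, the lowest of the two numbers measured so far; compound 1 `COc1ccc(CN(C(=O)CSc2nc3ccccc3s2)c2cc(OC)c(OC)c(OC)c2)cc1F` gives 20100 nM. Going by the values given here, the only measured step, a 2.7-fold lower number from compound 1 to compound 2 (0.43 log units; beyond the scatter), runs between fluoro and amino, not between amino and methoxy, so it is at best an indirect guide. Compound 3 `COc1ccc(CN(C(=O)CSc2nc3ccccc3s2)c2cc(OC)c(OC)c(OC)c2)cc1OC` carries the change (methoxy in place of amino on an aromatic carbon). Among the compounds with values here, with the amino group gone, a modest rise in the number toward that of compound 1 seems the likeliest outcome, though no step directly supports this. Compound 3 is therefore expected to give 12000 nM, between 4000 nM and 40000 nM, an estimated step of a 1.6-fold higher number from compound 2 to compound 3 (0.20 log units; within the scatter).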

Compound 3, half-maximal inhibitory concentration: > 80000 nM
Compound 3 was reported as a limit (the forecaster's own chance of this, stated with the estimate: 5%); middle value at least 6.6-fold (0.82 log units) from the limit.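

Compound 3 is reported in this assay only as a limit: the limit of > 80000 nM in this assay, at which 1 of the 3 values shown sits.

Even so, methoxy in place of amino brings an at least 10-fold higher number from compound 2 to compound 3 (1.02 log units; beyond the scatter), and methoxy in place of fluoro brings an at least 3.9-fold higher number from compound 1 to compound 3 (0.59 log units; beyond the scatter). The three groups at this position therefore fall in the order amino, fluoro, methoxy, from lowest number to highest, so this one change can shift the result strongly.

As far as these compounds go, how far compound 3 lies past its limit remains open, and with it the true size of both steps. Also open, from the compounds shown here alone, is where a hydroxyl or dimethylamino group at this position would fall in that order.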